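Inverting one ring stereocentre in the benzylamide

This account rests on a few compounds, and the source may have more. Where it says the series, first, only, none or still open, it means among the compounds named here.

In a functional assay on QGY cells (Homo sapiens) for cytotoxicity, read by MTT assay, with a stated time of 48 h (on this read-out higher numbers stand for weaker inhibition and lower numbers for stronger inhibition), compound 2 `COc1cc([C@@H]2C[C@@]2(CO)C(=O)NCc2ccc(C)cc2)cc(OC)c1OC` gives 58700 nM, compound 1 `COc1cc([C@@H]2C[C@@]2(CO)C(=O)Nc2ccccc2)cc(OC)c1OC` gives 36700 nM and compound 3 `COc1cc([C@@H]2C[C@@]2(CO)C(=O)Nc2ccccc2Cl)cc(OC)c1OC` gives 24500 nM. Compound 2 sits within the scatter of compound 1, as a 1.6-fold higher number from compound 1 to compound 2 (0.20 log units; within the scatter) shows, while a 2.4-fold lower number from compound 2 to compound 3 (0.38 log units; beyond the scatter) lies beyond it. Compound 1 and compound 3 also agree within the scatter, at a 1.5-fold lower number from compound 1 to compound 3 (0.18 log units; within the scatter). Compound 4 `COc1cc([C@H]2C[C@@]2(CO)C(=O)NCc2ccc(C)cc2)cc(OC)c1OC` differs from compound 2 only in configuration: the two compounds have the same atoms and bonds and differ only in configuration as drawn: 1 of 2 stereo elements differ; a stereocentre at a saturated ring carbon is drawn S in compound 2 and R in compound 4. Among the compounds with values here, no measured step changes configuration, so these amide-side steps, all small, give only a loose guide. No step beyond the scatter is expected, and no direction is favoured. The expected change is a 1.1-fold lower number from compound 2 to compound 4 (0.05 log units; within the scatter). For compound 4 the estimate is 52000 nM, with an expected range of 22000 nM to 110000 nM.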

Compound 4, half-maximal inhibitory concentration: > 100000 nM
Compound 4 ended at the assay's limit; the forecaster's own chance of this, stated with the estimate: 10%; middle value at least 1.9-fold (0.28 log units) away from the limit.
By their numbers in this assay, from the lowest: compounds 3, 1 and 2 (each within the scatter of the next, the first and the last beyond it). At a limit, above all of these: compound 4.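

Compound 4 gives > 100000 nM in this assay, which is a limit of the assay and not a number. The step reads an at least 1.7-fold higher number from compound 2 to compound 4 (0.23 log units; that floor lies within the scatter), so only a floor is known for this ring stereocentre, and the true size of the change stays unread: the limit of > 100000 nM in this assay, at which 1 of the 4 values shown sits. Unlike the earlier steps, all on the amide side, this one isolates configuration alone: the fact that compounds 2 and 4 differ only in the configuration as drawn.

As far as these compounds go, whether the same inversion shifts the phenyl amide of compound 1 or the 2-chlorophenyl amide of compound 3 remains open. Also open, from the compounds shown here alone, is how an amine or a carboxylic acid on the amide side would read in either configuration.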